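From Methylamino to Dimethylamino on the Shared Core

The compounds below may be only part of what the source reports. "The series", "measured", "known", "first", "only" and "open" are said of these compounds alone.

Compound 1, `Nc1nc2c(nc(Br)n2COCCO)c(=O)[nH]1`, gives in a functional assay on L1210 cells (Mus musculus) for inhibition (a higher number here means a weaker inhibitor, a lower number a stronger inhibitor), a value of > 500 ug/mL, which is a limit of the assay and not a number.
Compound 2, `Nc1nc2c(nc(O)n2COCCO)c(=O)[nH]1`, gives in this assay a value of > 500 ug/mL, again a limit of the assay.
Compound 3, `CNc1nc2c(=O)[nH]c(N)nc2n1COCCO`, gives in this assay a value of > 500 ug/mL, once more a limit of the assay.

Compound 3 therefore stands at the limit of > 500 ug/mL in this assay, at which 3 of the 3 values shown sit. No measured step can be read: a step that the two limits leave unreadable from compound 1 to compound 2, a step that the two limits leave unreadable from compound 1 to compound 3 and a step that the two limits leave unreadable from compound 2 to compound 3 are all unreadable because each end is a limit. Among the compounds with values here, the variations so far concern the group on an aromatic carbon of the shared core; none of them changed the reading of this assay beyond the limit.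

Compound 4, `CN(C)c1nc2c(=O)[nH]c(N)nc2n1COCCO`, differs from compound 3 by methyl in place of hydrogen on a nitrogen on an aromatic ring. Within the data shown here, this change touches the methylamino group of compound 3 rather than the carbon substituent varied before, so no measured step bears on it directly. With every compound shown at the limit, the expectation for this assay is a step of no readable size in either direction: a number no higher from compound 3 to compound 4 (the limit leaves the size open) is expected to be unreadable as well. Compound 4 is thus estimated at 500 ug/mL, within a range of 150 ug/mL to 2000 ug/mL, most likely reported only as a limit.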

Compound 4, concentration for 50% inhibition: > 500 ug/mL
Compound 4 was reported as a limit (the forecaster's own chance of this, stated with the estimate: 85%); the middle value sits exactly at the limit.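

In this assay compound 4 gives > 500 ug/mL, which is a limit of the assay. Its steps from compound 1, compound 2 and compound 3 cannot be read, because both ends of each step are limits: the limit of > 500 ug/mL in this assay, at which 4 of the 4 values shown sit.

The compounds shown leave open how these four truly differ in this assay, and whether any group on the shared core would give a readable value.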